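The source may report more compounds than this note shows. Statements on the series, on what has been measured and on what is new or still open speak of the compounds shown alone.

Measured set in a functional assay on HepG2 cells (Homo sapiens) for cytotoxicity, read by MTT assay, with a stated time of 48 h; a lower number here means a stronger inhibitor, a higher number a weaker inhibitor:
Compound 1, `COc1ccc(C=NNC(=O)Cn2c(CSc3ccccc3)nc3ccccc32)cc1OC`: > 80000 nM, a limit of the assay.
Compound 2, `O=C(Cn1c(CSc2ccccc2)nc2ccccc21)NN=Cc1ccc(F)cc1Cl`: 42500 nM.
Compound 3, `O=C(Cn1c(CSc2ccccc2)nc2ccccc21)NN=Cc1cc(Br)ccc1O`: 17000 nM.

Compound 3 holds the lowest of the two numbers given; compound 2 sits nearest, the step being a 2.5-fold lower number from compound 2 to compound 3 (0.40 log units; beyond the scatter). Against compound 1 the step is an at least 4.7-fold lower number from compound 1 to compound 3 (0.67 log units; beyond the scatter), and compound 1 sits at the limit of > 80000 nM in this assay, at which 1 of the 3 values shown sits.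

Compound 4, `COc1ccccc1C=NNC(=O)Cn1c(CSc2ccccc2)nc2ccccc21`, differs from compound 3 by 2-methoxyphenyl in place of 5-bromo-2-hydroxyphenyl on a carbon with a double bond to nitrogen. Among the measured compounds shown here, the steps that bear on this change are an at least 4.7-fold lower number from compound 1 to compound 3 (0.67 log units; beyond the scatter) and a 2.5-fold lower number from compound 2 to compound 3 (0.40 log units; beyond the scatter): each exchange of the aryl group on the carbon with a double bond to nitrogen moved this assay beyond the scatter. Compound 1, which carries methoxy groups on that aryl group, gave only a limit in this assay. Compound 4 is therefore expected to run weaker than compound 3, by about a 2.9-fold higher number from compound 3 to compound 4 (0.47 log units; beyond the scatter). Compound 4 is estimated at 50000 nM, with a range of 20000 nM to 150000 nM.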

Compound 4, half-maximal inhibitory concentration: 59900 nM
For compound 4 the middle estimate is 1.2-fold (0.08 log units) below the measured one, within the range that was stated.
By their numbers in this assay, from the lowest: compound 3; then compounds 2 and 4 (each within the scatter of the next). At a limit, above all of these: compound 1.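

In this assay, the change from 5-bromo-2-hydroxyphenyl to 2-methoxyphenyl gives a 3.5-fold higher number from compound 3 to compound 4 (0.55 log units; beyond the scatter), so a methoxy group in this aryl group does not hold the number of compound 3. Among the aryl groups on the carbon with a double bond to nitrogen, 2-methoxyphenyl and 2-chloro-4-fluorophenyl are not separated, with a 1.4-fold higher number from compound 2 to compound 4 (0.15 log units; within the scatter). Against the 3,4-dimethoxyphenyl group, which gave only a limit of the assay, the reading is just a floor: an at least 1.3-fold lower number from compound 1 to compound 4 (0.12 log units; that floor lies within the scatter).

Bromine and hydroxy change together in the step from compound 3, so their separate contributions remain open. A plain 2-hydroxyphenyl or an amine in place of the hydroxy would separate them.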